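A few compounds are considered here, and "the series" means these few. Any claim that something is new, unique, unknown or untested is made for them only; others in the source may bear on it.

Measured compounds, in a functional assay on SiHa cells (Homo sapiens) for inhibition, read by sulforhodamine B assay; on this read-out higher numbers stand for weaker inhibition of growth and lower numbers for stronger inhibition of growth:

Compound 1 `CN(C)c1ccc(-c2ccc(-c3ccc(-c4nc5ccccc5[nH]4)cc3)cc2)cc1`: 100000 nM
Compound 2 `COc1ccc(-c2ccc(-c3ccc(-c4nc5ccccc5[nH]4)cc3)cc2)cc1OC`: 6200 nM
Compound 3 `COc1cc(-c2ccc(-c3ccc(-c4nc5ccccc5[nH]4)cc3)cc2)cc(OC)c1OC`: 4980 nM

Compound 2 sits second highest of the three numbers. Its nearest neighbour is compound 3, reached by a 1.2-fold lower number from compound 2 to compound 3 (0.10 log units; within the scatter), a difference that stays within the usual scatter. Among the compounds with values here, the furthest is compound 1: the move a 16-fold lower number from compound 1 to compound 2 (1.21 log units; beyond the scatter) is the only large step, and it concerns the aryl group at the end of the chain remote from the fused system.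

Compound 4 `COc1ccc(-c2ccc(-c3ccc(-c4nc5c(O)cccc5[nH]4)cc3)cc2)cc1OC` is the next compound to be measured in this assay. It differs from compound 2 by hydroxy in place of hydrogen on an aromatic carbon. Within the data shown here, neither measured step touches this part of the shared core: both a 16-fold lower number from compound 1 to compound 2 (1.21 log units; beyond the scatter) and a 1.2-fold lower number from compound 2 to compound 3 (0.10 log units; within the scatter) alter the terminal aryl ring only, so there is no direct precedent for a hydroxy added to the six-membered aromatic ring of the fused system. Among the measured compounds shown here, the one small substituent addition on record, a methoxy in place of hydrogen giving a 1.2-fold lower number from compound 2 to compound 3 (0.10 log units; within the scatter), stayed within the scatter, which is the only guide available. The expected step of a 1.1-fold lower number from compound 2 to compound 4 (0.05 log units; within the scatter) is therefore no change beyond the scatter, in either direction, with a wide band of uncertainty. The estimate for compound 4 in this assay is 5500 nM, within 1500 nM to 20000 nM.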

Compound 4, concentration for 50% growth inhibition: 1110 nM
Estimate against measurement, compound 4: 5.0-fold (0.70 log units) above; measured number outside the range, below it.
By their numbers in this assay, from the lowest: compound 4; then compounds 3 and 2 (each within the scatter of the next); then compound 1.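

In this assay, within the data shown here, the step of a 5.6-fold lower number from compound 2 to compound 4 (0.75 log units; beyond the scatter) is the first change on record to the shared core, and it lies beyond the scatter, which shows that this carbon of the six-membered aromatic ring is a place where one added group can shift the number towards stronger inhibition of growth. The other single addition shown, the methoxy in a 1.2-fold lower number from compound 2 to compound 3 (0.10 log units; within the scatter), sits on the terminal aryl ring and stays within the scatter, so among these compounds an addition of this small kind moves the number only in the change from 1H-benzimidazol-2-yl to 4-hydroxy-1H-benzimidazol-2-yl. No supporting measurement is available to account for this step.

As far as these compounds go, it remains open whether the shift is specific to the hydroxy, since a methoxy, an amine or a fluorine on the same carbon would test that, as would a hydroxy on the other carbons of that ring. From the compounds shown here alone, it is also open whether the same hydroxy would give a step of similar size on compound 3 or compound 1, whose terminal aryl groups differ from that of compound 2.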